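Hydroxynaphthyl hydrazone in place of the naphthyl analogue

The source may report more compounds than this note shows. Statements on the series, on what has been measured and on what is new or still open speak of the compounds shown alone.

Compound 1: `CCCSc1nc(N/N=C/c2ccccc2F)c2nnn(Cc3ccccc3)c2n1`, > 64000 nM
Compound 2: `CCCSc1nc(N/N=C/c2ccccc2Cl)c2nnn(Cc3ccccc3)c2n1`, 13800 nM
Compound 3: `CCCSc1nc(N/N=C/c2ccc3ccccc3c2)c2nnn(Cc3ccccc3)c2n1`, > 64000 nM

In a functional assay on MCF7 cells (Homo sapiens) for antiproliferative activity, read by MTT assay, with a stated time of 72 h (a lower number here means a stronger inhibitor, a higher number a weaker inhibitor), compound 3 gives > 64000 nM, which is a limit of the assay and not a number. Compound 1 likewise sits at a limit, > 64000 nM, so that (the limit of > 64000 nM in this assay, at which 2 of the 3 values shown sit). Only compound 2 gives a number, 13800 nM; the step of an at least 4.6-fold lower number from compound 1 to compound 2 (0.66 log units; beyond the scatter) is beyond the scatter, and so is an at least 4.6-fold higher number from compound 2 to compound 3 (0.66 log units; beyond the scatter), whereas a step that the two limits leave unreadable from compound 1 to compound 3 cannot be read because both ends are limits.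

Compound 4, `CCCSc1nc(N/N=C/c2c(O)ccc3ccccc23)c2nnn(Cc3ccccc3)c2n1`, differs from compound 3 by 2-hydroxynaphthalen-1-yl in place of naphthalen-2-yl on a carbon with a double bond to nitrogen. Among the measured compounds shown here, no measured step exchanges a naphthalen-2-yl for a 2-hydroxynaphthalen-1-yl, and none adds a hydroxyl, so the measured steps bear on it only through the position of compound 3 at the limit: from a limit, only a lower number can be read at all. The expectation for compound 4 is therefore wide and weakly held; its estimated step is an at least 2.1-fold lower number from compound 3 to compound 4 (0.32 log units; beyond the scatter). Compound 4 is estimated at 30000 nM, within 6000 nM to 128000 nM, with a real chance that the assay again reports only a limit.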

Compound 4, half-maximal inhibitory concentration: 6400 nM
For compound 4 the middle estimate is 4.7-fold (0.67 log units) above the measured one; measured number inside the range.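

On the carbon with a double bond to nitrogen, a naphthalene-based group does not by itself leave a compound at the limit of this assay: 2-hydroxynaphthalen-1-yl in place of naphthalen-2-yl gives an at least 10-fold lower number from compound 3 to compound 4 (1.00 log units; beyond the scatter). Among the compounds shown here, the same group also improves on the only earlier compound with a true number, giving a 2.2-fold lower number from compound 2 to compound 4 (0.33 log units; beyond the scatter), and against the 2-fluorophenyl compound it gives an at least 10-fold lower number from compound 1 to compound 4 (1.00 log units; beyond the scatter), so compound 4 now has the lowest number of the four. Compound 1 and compound 3 remain limits and not numbers, so the steps from them to compound 4 give only a bound on the size of the change: the limit of > 64000 nM in this assay, at which 2 of the 4 values shown sit.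

The change from naphthalen-2-yl to 2-hydroxynaphthalen-1-yl alters both the attachment to the naphthalene and the presence of the hydroxyl, and the compounds shown do not separate the two. As far as these compounds go, it remains open whether a plain naphthalen-1-yl group, or a methoxy group in place of the hydroxyl, would hold the number of compound 4 or fall back towards the limit.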